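Ester cleavage on the hydroxymethyl arm: a second instance

The source may hold more compounds than are shown below. What is called first, only, known or untested is meant among the compounds shown, and "the series" means these compounds.

The measured compounds:
Compound 1, `NS(=O)(=O)c1ccc(-n2nc(C(F)(F)F)cc2-c2ccc3c(c2)CCO3)cc1CO`, gives 22.3 mg/kg in a functional assay on the whole organism (strain Wistar) with Rattus norvegicus as the target, read by paw edema; a lower number here means that less compound is needed, a higher number that more compound is needed for the effect.
Compound 2, `CCC(=O)OCc1cc(-n2nc(C(F)(F)F)cc2-c2ccc3c(c2)CCO3)ccc1S(N)(=O)=O`, gives 8.5 mg/kg in this assay.
Compound 3, `CCC(=O)NS(=O)(=O)c1ccc(-n2nc(C(F)(F)F)cc2-c2ccc3c(c2)CCC3)cc1COC(=O)CC`, gives 64 mg/kg in this assay.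

Compound 3 stands highest of the three numbers, and its step to either of the others lies beyond the scatter. Compound 3 and compound 2 differ in more than one place, and the difference between the two cores is not broken down here.

Going by the values given here, the one change that is traced twice in this set is hydrogen in place of propanoyl on an oxygen on a saturated carbon. Between the measured pair it made a modest step, a 2.6-fold higher number from compound 2 to compound 1 (0.42 log units; beyond the scatter), so the hydroxymethyl compound 1 needs more than the ester compound 2.

Compound 4, `CCC(=O)NS(=O)(=O)c1ccc(-n2nc(C(F)(F)F)cc2-c2ccc3c(c2)CCC3)cc1CO`, has not yet been measured in this assay. It arises from compound 3 by hydrogen in place of propanoyl on an oxygen on a saturated carbon, the same change on the same kind of place as before, with the place described in identical terms. Among the compounds with values here, since the only guide is the step from compound 2 to compound 1, compound 4 is expected to move in the same direction by a similar amount, a 2.3-fold higher number from compound 3 to compound 4 (0.37 log units; beyond the scatter), because compound 3 already gives 64 mg/kg and the earlier step was a 2.6-fold higher number from compound 2 to compound 1 (0.42 log units; beyond the scatter). On that basis compound 4 is estimated at 150 mg/kg, between 60 mg/kg and 380 mg/kg.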

Compound 4, dose for half-maximal effect: 52 mg/kg
Beside the measured number, compound 4's estimate is 2.9-fold (0.46 log units) above it, and the stated range ends above it.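

In this assay, hydrogen in place of propanoyl on an oxygen on a saturated carbon gave a 1.2-fold lower number from compound 3 to compound 4 (0.09 log units; within the scatter), so on this core the ester and the hydroxymethyl form cannot be told apart. The change therefore did not carry over at the same size from the core of compound 1 to the core of compound 4: the same change on two cores in this assay, a 2.6-fold higher number (0.42 log units; beyond the scatter) from compound 2 to compound 1 and a 1.2-fold lower number (0.09 log units; within the scatter) from compound 3 to compound 4, 3.2-fold (0.51 log units) apart, beyond the scatter of two such steps. With only these two pairs, the result shows that the step seen on one core was no reliable guide to the step on the other, but it does not show why they differ or how the change would behave on any further core.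

The two cores differ in more than one place, and no pair shown separates those differences, so it remains open which of them goes with the loss of the step. Also open, on these data alone, is whether a shorter acetyl group or a longer butanoyl chain on the same oxygen would give a step like that on the core of compound 1 or like that on the core of compound 4.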